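The compounds below may be only part of what the source reports. "The series", "measured", "known", "first", "only" and "open" are said of these compounds alone.

Working notes on the series. Compound 1 `COC1(/C=C/COCc2ccc3c(ccc(=O)n3C)c2)CCOCC1`, compound 2 `CO/C(=C\C(=O)OCc1ccc2c(ccc(=O)n2C)c1)C1(OC)CCOCC1` and compound 3 `COC1(C(=O)CC(=O)OCc2ccc3c(ccc(=O)n3C)c2)CCOCC1` share one core and differ only in the linking chain carried on the saturated ring. The measure used is a functional assay on the whole organism for inhibition, with Rattus norvegicus as the target, with a stated time of 3 h; a lower number here means that less compound is needed, a higher number that more compound is needed for the effect. In this assay compound 1 gives > 5 mg/kg, which is a limit of the assay and not a number. In this assay compound 2 gives > 5 mg/kg, again a limit rather than a number. In this assay compound 3 gives > 5 mg/kg, also a limit. Among the compounds with values here, compound 2 therefore stands nowhere apart from the others: it sits at the limit of > 5 mg/kg in this assay, at which 3 of the 3 values shown sit, where compound 1 and compound 3 sit as well, and no step between any pair of them can be read from the numbers so far. Compound 4 `COC1(/C(C)=C/C(=O)OCc2ccc3c(ccc(=O)n3C)c2)CCOCC1` is not yet measured. It differs from compound 2 by methyl in place of methoxy on a double-bonded chain carbon bound to a double-bonded chain carbon and a saturated ring carbon. Within the data shown here, no measured step bears on this change, and the three values together point in no direction. In this assay the expected step is a step that the limit leaves unreadable from compound 2 to compound 4, that is, none beyond the scatter, and a limit rather than a number remains the most probable outcome. For compound 4 in this assay the estimate is 8 mg/kg, with a range from 2 mg/kg to 30 mg/kg.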

Compound 4, dose for half-maximal effect: > 5 mg/kg
Compound 4 ended at the assay's limit; the forecaster's own chance of this, stated with the estimate: 70%; the middle value lies beyond the limit too.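

In this assay compound 4 gives > 5 mg/kg, a limit of the assay and not a number. Compound 2 also stands at a limit, so no step can be read between compound 2 and compound 4 for methyl in place of methoxy: the limit of > 5 mg/kg in this assay, at which 4 of the 4 values shown sit.

The compounds shown leave open whether any linking chain on the shared core reaches a measurable dose for half-maximal effect.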